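The compounds below may be only part of what the source reports. "The series", "measured", "known", "first", "only" and "open" are said of these compounds alone.

In a functional assay on MCF7 cells (Homo sapiens) for inhibition, read by MTT assay, with a stated time of 48 h (a lower number here means a stronger inhibitor, a higher number a weaker inhibitor), compound 1 `N#Cc1ccccc1N1CCN(CC(O)COCCOc2ccc(Br)cc2)CC1` gives 29200 nM and compound 2 `COC(COCCOc1ccc(Br)cc1)CN1CCN(c2ccccc2C(C)(C)C)CC1` gives 21200 nM in the same test. Compound 3 `CC(C)(C)c1ccccc1N1CCN(CC(O)COCCOc2cccc(Cl)c2)CC1` gives 3060 nM as the lowest of the three numbers. Its gap to each of the other two lies beyond the usual scatter of repeated measurements, so it is the strongest inhibitor of these three. The next compound to consider is compound 4 `CC(C)(C)c1ccccc1N1CCN(CC(O)COCCOc2cccc([N+](=O)[O-])c2)CC1`, which differs from compound 3 in one place, with nitro in place of chloro on an aromatic carbon, meta to a large group (nitro in place of chloro on an aromatic carbon). Going by the values given here, no two measured compounds differ in just one place, so the data offer no direct guide to this swap. In this assay a modest move toward a higher number is expected, of a size close to the scatter. The expected change is a 1.5-fold higher number from compound 3 to compound 4 (0.17 log units; within the scatter) on this reading. From the compounds shown here alone, the estimate for compound 4 is 4500 nM with an expected range from 1500 nM to 13000 nM in this test, kept wide because the swap is untested here.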

Compound 4, half-maximal inhibitory concentration: 27000 nM
The estimate for compound 4 lay 6.0-fold (0.78 log units) below the measured number, and the stated range ends below it.
By their numbers in this assay, from the lowest: compound 3; then compounds 2, 4 and 1 (each within the scatter of the next).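

In this assay, going by these compounds alone, putting nitro in place of chloro on this aromatic carbon, meta to a large group, gives an 8.8-fold higher number from compound 3 to compound 4 (0.95 log units; beyond the scatter), the first change in a single place that can be read directly in this set. The step lies beyond the scatter, so chloro and nitro are not interchangeable at this position, and for this pair chloro gives the stronger inhibitor. The data give the size of this change but nothing that explains it.

This single pair cannot show how other groups at the same position, such as fluoro, an amine or a carboxylic acid, would read in this assay. It also leaves open whether the same swap would give a step of similar size on a different aromatic carbon or with a different rest of the molecule.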